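This account rests on a few compounds, and the source may have more. Where it says the series, first, only, none or still open, it means among the compounds named here.

In a functional assay on A549 cells (Homo sapiens) for antiproliferative activity, read by MTT assay, with a stated time of 72 h (on this read-out higher numbers stand for weaker inhibition and lower numbers for stronger inhibition), compound 1 (`COc1cc(-n2cnc3ccc(-c4ccccc4)cc32)cc(OC)c1OC`) gives 3060 nM. Compound 2 (`COc1cc(-n2cnc3ccc(-c4ccc(Cl)cc4)cc32)cc(OC)c1OC`) gives > 10000 nM, which is only a limit of the assay. Among the compounds with values here, the one measured step bearing on what follows is an at least 3.2-fold higher number from compound 1 to compound 2 (0.51 log units; beyond the scatter), with chloro in place of hydrogen on an aromatic carbon. Compound 3 (`COc1cccc(-c2ccc3ncn(-c4cc(OC)c(OC)c(OC)c4)c3c2)c1`) has 3-methoxyphenyl in place of 4-chlorophenyl on an aromatic carbon. Within the data shown here, it lacks that chloro, as does compound 1 at 3060 nM, so a lower number of modest size is expected in this assay, although no methoxy compound has been measured. The expected change is an at least 2.5-fold lower number from compound 2 to compound 3 (0.39 log units; beyond the scatter). The estimate for compound 3 is 4000 nM, with a range of 1300 nM to 12000 nM.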

Compound 3, half-maximal inhibitory concentration: 3180 nM
Beside the measured number, compound 3's estimate is 1.3-fold (0.10 log units) above it, within the range that was stated.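

In this assay, the 3-methoxyphenyl group on this aromatic carbon shows that a substituted phenyl ring can stand here without the loss seen with 4-chlorophenyl: an at least 3.1-fold lower number from compound 2 to compound 3 (0.49 log units; beyond the scatter). Set against the unsubstituted phenyl, the methoxy group makes no difference beyond the scatter: a 1.0-fold higher number from compound 1 to compound 3 (0.02 log units; within the scatter). The value for compound 2 is a limit, so the first step gives only a bound: the limit of > 10000 nM in this assay, at which 1 of the 3 values shown sits.

The compounds shown leave open whether an amine or a carboxylic acid in place of the methoxy group would keep this level of activity. They also leave open whether any group here would give a lower number than compound 1 gives.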